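Lengthening the alkyne chain one carbon further

The compounds below may be only part of what the source reports. "The series", "measured", "known", "first", "only" and "open" are said of these compounds alone.

Compound 1 `C#CCN(CC[C@H](N)C(=O)O)C[C@H]1O[C@@H](n2cnc3c(N)ncnc32)[C@H](O)[C@@H]1O` and compound 2 `CC#CCN(CC[C@H](N)C(=O)O)C[C@H]1O[C@@H](n2cnc3c(N)ncnc32)[C@H](O)[C@@H]1O` share a core and differ only at the tip of the triple-bonded chain. In an assay for binding affinity to tRNA (cytosine(38)-C(5))-methyltransferase (Homo sapiens), read by isothermal titration calorimetry, tested at 100 uM (on this read-out higher numbers stand for weaker binding and lower numbers for tighter binding), compound 1 gives 11400 nM, and in this assay compound 2 gives 10400 nM. The step of a 1.1-fold lower number from compound 1 to compound 2 (0.04 log units; within the scatter) shows that the two numbers sit within the scatter of each other, so compound 2 cannot be told apart from compound 1 on these figures. Compound 3 `CCC#CCN(CC[C@H](N)C(=O)O)C[C@H]1O[C@@H](n2cnc3c(N)ncnc32)[C@H](O)[C@@H]1O` carries the same change once more: methyl in place of hydrogen on a saturated chain carbon bound to a triple-bonded carbon. Going by the values given here, the only step that bears on this, the one from compound 1 to compound 2, produced no shift beyond the scatter, so the same is expected here, with the step of a 1.0-fold lower number from compound 2 to compound 3 (0.02 log units; within the scatter) expected to be small. For compound 3 the estimate in this assay is 10000 nM, within a range from 5000 nM to 22000 nM.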

Compound 3, dissociation constant: 10500 nM
Estimate against measurement, compound 3: 1.1-fold (0.02 log units) below; the measured number falls inside the stated range.
By their numbers in this assay, from the lowest: compounds 2, 3 and 1 (each within the scatter of the next).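

In this assay the methyl on the saturated chain carbon bound to a triple-bonded carbon gives a 1.0-fold higher number from compound 2 to compound 3 (0.00 log units; within the scatter) and the two changes taken as one give a 1.1-fold lower number from compound 1 to compound 3 (0.04 log units; within the scatter). The earlier pair covered only a single added carbon, whereas this series shows that a second added carbon, and the two together, also leave binding indistinguishable within the scatter, so hydrogen, methyl and ethyl on the triple-bonded carbon cannot be told apart on these numbers. No measurement at hand offers an explanation for this flat result.

The compounds shown leave open whether a longer chain, a phenyl ring or an amine on the triple-bonded carbon would give the same picture. They also leave open whether a carboxylic acid there would shift binding beyond the scatter.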